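The source may report more compounds than this note shows. Statements on the series, on what has been measured and on what is new or still open speak of the compounds shown alone.

Compound 1 `COc1cc(/C=C/C(=O)/C=C(/C=C/c2ccc(O)c(OC)c2)NCCCO)ccc1O` gives 25400 nM in a physicochemical assay for solubility, using the shake flask method, in phosphate buffer, with a stated time of 90 min, at pH 6.8; a higher number here means a more soluble compound, a lower number a less soluble compound.
Compound 2 `COCCCNC(=C\C(=O)/C=C/c1ccc(O)cc1)/C=C/c1ccc(O)cc1` gives 10500 nM in this assay.

Of these two numbers, compound 2 holds the lower one, and the gap up to compound 1 lies beyond the usual scatter. Compound 3 `O=C(/C=C(/C=C/c1ccc(O)cc1)NCCO)/C=C/c1ccc(O)cc1` differs from compound 2 by a single change: hydroxy in place of methoxymethyl on a saturated chain carbon, two bonds along the chain from an amine nitrogen. Within the data shown here, no measured pair shows this same change, so its size is unknown here. Compound 3 is expected to come out a little higher than compound 2, with the step estimated as a 1.7-fold higher number from compound 2 to compound 3 (0.23 log units; within the scatter), a small rise that may not exceed the scatter. Compound 3 is accordingly estimated at 18000 nM, within a range from 7000 nM to 45000 nM.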

Compound 3, solubility: 38700 nM
Beside the measured number, compound 3's estimate is 2.2-fold (0.33 log units) below it; low and high end bracket the measured number.
By their numbers in this assay, from the lowest: compound 2; then compounds 1 and 3 (each within the scatter of the next).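

Among these compounds, the position on the amine chain is not silent: replacing (3-methoxypropyl)amino with (2-hydroxyethyl)amino gives a 3.7-fold higher number from compound 2 to compound 3 (0.57 log units; beyond the scatter) in this assay, the first step here that can be read, and it lies beyond the scatter. This single step carries two differences at once, a shorter chain and a hydroxy end in place of a methoxy end.

On these data alone, how much each contributes stays open, as does whether a carboxylic acid or an amine at the chain end would move the number further. Nothing shown gives a reason for the rise.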